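A few compounds are considered here, and "the series" means these few. Any claim that something is new, unique, unknown or untested is made for them only; others in the source may bear on it.

Measured in an ADME assay on L929 cells (Mus musculus) for cytotoxicity, read by resazurin assay, with a stated time of 72 h (a lower number here means a stronger inhibitor, a higher number a weaker inhibitor), so far:
- compound 1 `O=C(/C=C/c1ccc2c(c1)B(O)OC2)c1ccc(Br)cc1` gives > 10 ug/mL (a limit)
- compound 2 `O=C(/C=C/c1ccc2c(c1)B(O)OC2)c1ccc(Cl)cc1` gives > 10 ug/mL (a limit)

Compound 2 stands only at the limit > 10 ug/mL and has no number. Both compounds share this limit (the limit of > 10 ug/mL in this assay, at which 2 of the 2 values shown sit). Compound 3 `CC(=O)Nc1ccc(C(=O)/C=C/c2ccc3c(c2)B(O)OC3)cc1` carries acetamido in place of chloro on an aromatic carbon, para to a large group (acetamido in place of chloro on an aromatic carbon). Among the measured compounds shown here, the one measured step (a step that the two limits leave unreadable from compound 1 to compound 2) has no readable size, so no size carries over, and in this assay no step beyond the scatter is expected in either direction. Expected is a step that the limit leaves unreadable from compound 2 to compound 3 with the direction left open. For compound 3 the estimate is 15 ug/mL with an expected range of 6 ug/mL to 40 ug/mL and a report as a limit is likely.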

Compound 3, half-maximal inhibitory concentration: > 10 ug/mL
Compound 3 ended at the assay's limit; the forecaster's own chance of this, stated with the estimate: 75%; the middle value does not contradict the limit.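

Compound 1, compound 2 and compound 3 all sit at a limit in this assay, so no step among them can be read: the limit of > 10 ug/mL in this assay, at which 3 of the 3 values shown sit.

The compounds shown leave open whether bromo, chloro and acetamido differ at all beyond that limit.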